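Urea-Linked Pyrimidine Anilines Tested on HCC827 Cells

The source may report more compounds than this note shows. Statements on the series, on what has been measured and on what is new or still open speak of the compounds shown alone.

Measured so far:
Compound 1 `COc1cc(NC(=O)Nc2cc(Nc3cccc(C(C)(C)C)c3)ncn2)cc(OC)c1`: 48.7%
Compound 2 `COc1ccc(Nc2cc(NC(=O)Nc3c(Cl)cccc3Cl)ncn2)cc1C`: 63.1%

In a functional assay on HCC827 cells (Homo sapiens) for inhibition, read by MTT assay, with a stated time of 48 h, tested at 10 uM (on this read-out lower numbers stand for less inhibition and higher numbers for more inhibition at the one concentration tested (going by the name of the read-out)), compound 1 gives 48.7%, the lowest of the two numbers recorded. Its nearest neighbour on this read-out is compound 2, which gives 63.1%, a number that lies higher by a gap beyond the usual scatter. The two compounds differ in more than one place, so nothing can be drawn from that gap about any single change.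

Compound 3 `COc1cc(NC(=O)Nc2cc(Nc3cc(Br)ccc3OC)ncn2)cc(OC)c1` has not yet been measured. It differs from compound 1 in one place: 5-bromo-2-methoxyphenyl in place of 3-(tert-butyl)phenyl on a nitrogen on an aromatic ring. Going by the values given here, no measured pair shows a change of this kind, so the data offer no step on which to rest a direction. Without such a step, the account expects the change from compound 1 to compound 3 to stay within the scatter, neither clearly up nor clearly down. Compound 3 is therefore estimated at 50%, with a range from 30% to 70%. This estimate amounts to an expected step of a number 1.3 percentage points higher from compound 1 to compound 3 (within the scatter).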

Compound 3, a percentage reported as inhibition, at one concentration (the size of the read-out at that concentration, not a potency): 76.3%
Estimate against measurement, compound 3: 26.3 percentage points below; the whole stated range lies below it.
By their numbers in this assay, from the lowest: compound 1; then compound 2; then compound 3.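

In this assay, going by these compounds alone, the change on a nitrogen on an aromatic ring from 3-(tert-butyl)phenyl to 5-bromo-2-methoxyphenyl gives a number 27.6 percentage points higher from compound 1 to compound 3 (beyond the scatter), the first step in this set that isolates a single place and shows that the group held there can move the read-out. The change keeps one six-membered aromatic ring of carbon only, but replaces a group of 10 heavy atoms, all carbon, with 0 hydrogen-bond acceptors by one of 9 heavy atoms, including oxygen and bromine, with 1 hydrogen-bond acceptor. No measurement shown here bears on why the read-out moves.

The bromine and the methoxy group enter together, so the compounds shown leave open how much of the step goes with each of them, or whether either alone would give a similar result. They also leave open how the read-out would respond to a different group on this aromatic ring, such as an amine or a carboxylic acid, and a single concentration gives no measure of potency.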